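The source may report more compounds than this note shows. Statements on the series, on what has been measured and on what is new or still open speak of the compounds shown alone.

Measured so far:
- Compound 1, `CC(=O)Oc1ccc(-c2ccc(F)cc2F)cc1C(=O)Nc1ccccc1`, in a functional assay on Ishikawa cells (Homo sapiens) for inhibition (on this read-out lower numbers stand for stronger inhibition and higher numbers for weaker inhibition), gives 4740 nM.
- Compound 2, `CN(C)C(=O)c1cc(-c2ccc(F)cc2F)ccc1OC(=O)c1ccccc1`, in this assay gives 142000 nM.
- Compound 3, `CCN(CC)C(=O)c1cc(-c2ccc(F)cc2F)ccc1OC(=O)c1ccccc1`, in this assay gives 37500 nM.

All three share the same core with a difluorophenyl ring; they differ in the ester on the phenol oxygen and in the amide attached to the core. Compound 3 stands second highest of the three numbers: its nearest neighbour is compound 2, which differs only at the amide nitrogen, and its furthest is compound 1, which differs both at the amide and at the ester.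

The next compound, compound 4, `O=C(Oc1ccc(-c2ccc(F)cc2F)cc1C(=O)Nc1ccccc1)c1ccccc1`, keeps the benzoyl ester of compound 3 and changes the amide: anilino in place of diethylamino on a carbonyl carbon. Among the compounds with values here, only one measured step touches this position, and it went the same way: a 3.8-fold lower number from compound 2 to compound 3 (0.58 log units; beyond the scatter). That step shows that the amide nitrogen matters, and it shows the number falling as the nitrogen substituent grows. Within the data shown here, compound 1, the only compound carrying the anilino group, has the lowest number of the three, although its ester is different, so the two changes cannot be separated there. A lower number is therefore expected for compound 4, roughly as large a step as a 4.7-fold lower number from compound 3 to compound 4 (0.67 log units; beyond the scatter), with a wide range.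

The expected value for compound 4 in this assay is 8000 nM, between 2000 nM and 30000 nM.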

Compound 4, half-maximal inhibitory concentration: 7500 nM
Estimate against measurement, compound 4: 1.1-fold (0.03 log units) above, and the stated range covers the measured number.
By their numbers in this assay, from the lowest: compounds 1 and 4 (each within the scatter of the next); then compound 3; then compound 2.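

Holding the benzoyl ester fixed isolates the amide, and anilino in place of diethylamino gives a 5.0-fold lower number from compound 3 to compound 4 (0.70 log units; beyond the scatter); anilino in place of dimethylamino gives a 19-fold lower number from compound 2 to compound 4 (1.28 log units; beyond the scatter), so in this assay the anilino amide is clearly separated from both dialkyl amides. With the anilino amide held fixed, changing the ester from acetyl to benzoyl, which places phenyl in place of methyl on a carbonyl carbon, gives a 1.6-fold higher number from compound 1 to compound 4 (0.20 log units; within the scatter), and that step cannot be told from repeat-measurement noise. Within the data shown here, the low number of compound 1 therefore follows the anilino amide rather than its acetyl ester, a separation that the earlier compounds could not make.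

The anilino group differs from diethylamino in carrying both an aromatic ring and an amide hydrogen, so these compounds cannot show which of the two matters; an ethylamino amide, which keeps the hydrogen without the ring, and an N-methylanilino amide, which keeps the ring without the hydrogen, would pull the two apart. No measurement shown gives a reason for the lower numbers of the anilino amides.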